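The compounds below may be only part of what the source reports. "The series", "measured", "known", "first", "only" and "open" are said of these compounds alone.

Among the measured compounds shown here, compound 1 `O=C(CSc1nnc(-c2ccncc2)o1)N/N=C/c1ccc([N+](=O)[O-])cc1` is the weakest of the three compounds measured so far in a functional assay on SW 1116 cells (Homo sapiens) for cytotoxicity, read by MTT assay, with a stated time of 48 h (on this read-out lower numbers stand for stronger inhibition and higher numbers for weaker inhibition), where compound 1 gives 25800 nM. Compound 2 `O=C(CSc1nnc(-c2ccncc2)o1)N/N=C/c1cc(Br)ccc1O` gives 8150 nM in this assay, and compound 3 `COc1cc(/C=N/NC(=O)CSc2nnc(-c3ccncc3)o2)ccc1O` gives 3590 nM. Both changes made to compound 1 lowered the number: a 3.2-fold lower number from compound 1 to compound 2 (0.50 log units; beyond the scatter), and a 7.2-fold lower number from compound 1 to compound 3 (0.86 log units; beyond the scatter). Between the two replacements themselves, a 2.3-fold lower number from compound 2 to compound 3 (0.36 log units; beyond the scatter).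

Compound 4 `O=C(CSc1nnc(-c2ccncc2)o1)N/N=C/c1ccc(Cl)cc1Cl` has not yet been measured in this assay. It differs from compound 1 in one place: 2,4-dichlorophenyl in place of 4-nitrophenyl on a carbon with a double bond to nitrogen. The two measured steps that bear on this change are the exchanges of the same 4-nitrophenyl group on the same carbon, each of which gave a modest lowering. Neither of them brought in a 2,4-dichlorophenyl group, and both entering groups carried hydrogen-bond donors and acceptors, which the 2,4-dichlorophenyl group does not, so the size of the coming step is uncertain. A modest lowering is nevertheless expected, since every exchange of the 4-nitrophenyl group seen so far has lowered the number. The expected step is a 2.6-fold lower number from compound 1 to compound 4 (0.41 log units; beyond the scatter). Compound 4 is therefore estimated at 10000 nM, with a range from 4000 nM to 26000 nM.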

Compound 4, half-maximal inhibitory concentration: 28900 nM
Compound 4: the middle estimate sits 2.9-fold (0.46 log units) below what was measured; the whole stated range lies below it.
By their numbers in this assay, from the lowest: compound 3; then compound 2; then compounds 1 and 4 (each within the scatter of the next).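

Among the compounds shown here, exchanging the 4-nitrophenyl group for 2,4-dichlorophenyl on this carbon is the first change at this position that leaves the number in this assay where it was (a 1.1-fold higher number from compound 1 to compound 4 (0.05 log units; within the scatter)), so replacing the 4-nitrophenyl group does not by itself lower the number. Set against the two groups that carry a hydroxy group, the 2,4-dichlorophenyl group gives clearly higher numbers (an 8.1-fold higher number from compound 3 to compound 4 (0.91 log units; beyond the scatter); a 3.5-fold higher number from compound 2 to compound 4 (0.55 log units; beyond the scatter)), and in these four compounds the lower numbers belong only to compound 2 and compound 3, with compound 1 and compound 4 together at the high end. Nothing at hand explains this split.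

The hydroxy group never appears alone in these compounds: it comes with a bromine in compound 2 and a methoxy group in compound 3, so its share of the lowering cannot be separated from that of its partner. A plain phenyl, a 4-hydroxyphenyl or a 4-aminophenyl group on the same carbon would be needed to tell whether the hydroxy group itself goes with the lower numbers, or whether other groups do as well.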